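From Compound 2 to Compound 3: A Triazole Exchange

The compounds below may be only part of what the source reports. "The series", "measured", "known", "first", "only" and "open" are said of these compounds alone.

In an ADME assay on SH-SY5Y cells (Homo sapiens) for cytotoxicity, read by MTT assay, with a stated time of 48 h (a lower number here means that less compound is needed, a higher number that more compound is needed for the effect), compound 1 `O=C(O)c1ccc(-c2ccccc2C(=O)NCCCCCCCn2cc(-c3cccnc3)nn2)cc1` gives 224 nM, while compound 2 `O=C(NCCCCCCCn1cc(-c2cccnc2)nn1)c1ccccc1-c1c[nH]nn1` gives 86.5 nM, the lower of the two numbers. Compound 3 `CN(C)Cc1cn(-c2ccccc2C(=O)NCCCCCCCn2cc(-c3cccnc3)nn2)nn1` differs from compound 2 as follows: 4-((dimethylamino)methyl)-1H-1,2,3-triazol-1-yl in place of 1H-1,2,3-triazol-4-yl on an aromatic carbon. Among the measured compounds shown here, only one measured step bears on this change, a 2.6-fold lower number from compound 1 to compound 2 (0.41 log units; beyond the scatter), and it involved a different exchange at the same place, so it indicates scale only. For the measured compounds named here, no measured compound carries the entering group, so the direction is uncertain, though a modest move toward a higher number is expected: a 1.5-fold higher number from compound 2 to compound 3 (0.18 log units; within the scatter). In this assay, the estimate for compound 3 is 130 nM, with an expected range of 45 nM to 380 nM.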

Compound 3, half-maximal effective concentration: 285 nM
Beside the measured number, compound 3's estimate is 2.2-fold (0.34 log units) below it; the measured number falls inside the stated range.
By their numbers in this assay, from the lowest: compound 2; then compounds 1 and 3 (each within the scatter of the next).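

At this position, on an aromatic carbon ortho to a large group, the exchange can also raise the number in this assay: 4-((dimethylamino)methyl)-1H-1,2,3-triazol-1-yl in place of 1H-1,2,3-triazol-4-yl gives a 3.3-fold higher number from compound 2 to compound 3 (0.52 log units; beyond the scatter) and so reverses the earlier gain. Set against 4-carboxyphenyl, the same entering group gives a 1.3-fold higher number from compound 1 to compound 3 (0.10 log units; within the scatter) and leaves those two groups unseparated. No evidence here accounts for the rise. On these data alone, the entering group differs both in its point of attachment and in its dimethylaminomethyl arm, so the share of each remains open. An unsubstituted 1H-1,2,3-triazol-1-yl group or a primary amine on that arm would bear on this question.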